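Anilino trifluoromethyl on the trimethoxyphenyl pyrazole enaminone

This account rests on a few compounds, and the source may have more. Where it says the series, first, only, none or still open, it means among the compounds named here.

Measured so far:
compound 1, `O=C(/C=C\Nc1ccc(C(F)(F)F)cc1)c1cn(-c2ccccc2)nc1-c1ccc(Cl)cc1`, > 50000 nM 
compound 2, `COc1ccc(-c2nn(-c3ccccc3)cc2C(=O)/C=C\Nc2ccc(C(F)(F)F)cc2)cc1`, > 50000 nM 
compound 3, `COc1cc(-c2nn(-c3ccccc3)cc2C(=O)/C=C\Nc2ccc(F)cc2)cc(OC)c1OC`, 25700 nM 

In an ADME assay on HaCaT cells (Homo sapiens) for antiproliferative activity, read by MTT assay, with a stated time of 48 h (on this read-out lower numbers stand for stronger inhibition and higher numbers for weaker inhibition), compound 1 reaches only the limit of the assay, > 50000 nM. Compound 2 likewise sits at a limit, > 50000 nM. Among the compounds with values here, compound 3 is the one compound of the three that gives a number, 25700 nM. Compound 1 and compound 2 both sit at the limit (the limit of > 50000 nM in this assay, at which 2 of the 3 values shown sit).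

Compound 4, `COc1cc(-c2nn(-c3ccccc3)cc2C(=O)/C=C\Nc2ccc(C(F)(F)F)cc2)cc(OC)c1OC`, differs from compound 3 by trifluoromethyl in place of fluoro on an aromatic carbon. Within the data shown here, no measured step shows this same change; the only step at hand, a step that the two limits leave unreadable from compound 1 to compound 2, is unreadable because both its ends are limits (the limit of > 50000 nM in this assay, at which 2 of the 3 values shown sit). Compound 1 and compound 2 both carry the trifluoromethyl on the anilino ring and both sit at the limit, while compound 3 carries fluoro there and gives a number, but the two ring substituents also differ, so no step can be read from this.

The expectation for compound 4 in this assay is therefore weak potency near the limit, with the step of a 1.8-fold higher number from compound 3 to compound 4 (0.24 log units; within the scatter) estimated toward weaker inhibition. Compound 4 is expected to give about 45000 nM, within 18000 nM to 110000 nM.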

Compound 4, half-maximal inhibitory concentration: > 50000 nM
Compound 4 gave a limit, no number (the forecaster's own chance of this, stated with the estimate: 55%); at least 1.1-fold (0.04 log units) between middle value and limit.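

In this assay, trifluoromethyl in place of fluoro on the anilino ring now has a direct reading, with all else held constant: an at least 1.9-fold higher number from compound 3 to compound 4 (0.28 log units; that floor lies within the scatter). That floor does not establish a real loss of inhibition at this position, though compound 4 gives only a limit, not a number, where compound 3 gives a number. The steps to compound 4 from compound 1 and compound 2 cannot be read, so the 3,4,5-trimethoxyphenyl group shows no measurable difference among the trifluoromethyl compounds, all of which stay at the limit: the limit of > 50000 nM in this assay, at which 3 of the 4 values shown sit.

On these data alone, how far above the limit compound 4 truly lies remains open. Also open, as far as these compounds go, is whether an amine or a carboxylic acid in place of fluoro on this ring would give a number in this assay.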